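The compounds below may be only part of what the source reports. "The series", "measured", "known", "first", "only" and "open" are said of these compounds alone.

Measured compounds:
- compound 1 `CNC(=O)c1cc(Oc2ccc(C(=O)/C=C/c3cccc(Br)c3)cc2)ccn1`: 10400 nM
- compound 2 `CNC(=O)c1cc(Oc2ccc(C(=O)/C=C/c3ccccc3)cc2)ccn1`: 5960 nM

Both compounds were tested in a functional assay on MCF7 cells (Homo sapiens) for cytotoxicity, read by MTT assay, with a stated time of 72 h; a higher number here means a weaker inhibitor, a lower number a stronger inhibitor. Compound 2, at 5960 nM, lies within the scatter of compound 1, at 10400 nM, so the two numbers cannot be ranked.

The next compound, compound 3 `CNC(=O)c1cc(Oc2ccc(C(=O)/C=C/c3ccc(F)cc3)cc2)ccn1`, differs from compound 2 by a single substitution fluoro in place of hydrogen on an aromatic carbon, para to a large group, turning phenyl into 4-fluorophenyl.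

Within the data shown here, one measured step bears on this change. Taking bromo away for hydrogen on an aromatic carbon gave a 1.7-fold lower number from compound 1 to compound 2 (0.24 log units; within the scatter). Among the measured compounds shown here, that step involves a different halogen, and no fluoro compound has been measured, so it offers only indirect guidance. For the measured compounds named here, still, the one halogen exchange available moved this assay by no more than the scatter, and a step beyond the scatter is therefore not expected here, in either direction.

The expected step is a 1.1-fold higher number from compound 2 to compound 3 (0.04 log units; within the scatter). For compound 3 the estimated value is 6500 nM, with an expected range from 3000 nM to 14000 nM.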

Compound 3, half-maximal inhibitory concentration: 28500 nM
The estimate for compound 3 lay 4.4-fold (0.64 log units) below the measured number; the measured number lies above the stated range.
By their numbers in this assay, from the lowest: compounds 2 and 1 (each within the scatter of the next); then compound 3.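

In this assay, the change from phenyl to 4-fluorophenyl gives a 4.8-fold higher number from compound 2 to compound 3 (0.68 log units; beyond the scatter) and is a modest step, but one beyond the scatter, unlike the exchange of bromo for hydrogen in the earlier pair. A halogen on this ring therefore does not leave the number unchanged in every case: 3-bromophenyl and phenyl could not be ranked, while the 4-fluorophenyl compound stands apart from both, with a 2.7-fold higher number from compound 1 to compound 3 (0.44 log units; beyond the scatter) as its step from the bromo compound. Nothing at hand accounts for this rise in the number, and the data give no reason for it.

The compounds shown leave open whether the higher number belongs to fluoro alone or would follow any group placed para to the large group, a question that 4-chlorophenyl, 4-methoxyphenyl or 4-aminophenyl analogues would address. On these data alone, it also stays open how much of the gap between the bromo and fluoro compounds comes from the halogen and how much from its place on the ring, as both differ in that one step.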